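Swapping tert-butyl for trifluoromethoxy on a shared core

This account rests on a few compounds, and the source may have more. Where it says the series, first, only, none or still open, it means among the compounds named here.

Compound 1 `O=C(O)COc1ccc(NC(=O)COc2ccccc2)cc1F`, compound 2 `CC(C)c1ccc(OCC(=O)Nc2ccc(OCC(=O)O)c(F)c2)cc1` and compound 3 `CC(C)(C)c1ccc(OCC(=O)Nc2ccc(OCC(=O)O)c(F)c2)cc1` share one core and differ only in a single group on one aromatic carbon. In a functional assay on CHO cells for agonist activity at Free fatty acid receptor 1 (Homo sapiens), read by FLIPR, tested at 100 nM (a higher number here means a stronger effect of the compound at the concentration tested, a lower number a weaker effect), compound 1 gives 29.8%, compound 2 gives 11.8% and compound 3 gives 7.65%, the lowest of the three numbers, though its gap to compound 2 lies within the scatter. Compound 4 `O=C(O)COc1ccc(NC(=O)COc2ccc(OC(F)(F)F)cc2)cc1F` differs from compound 3 by trifluoromethoxy in place of tert-butyl on an aromatic carbon. For the measured compounds named here, two measured steps bear on this: a number 22.2 percentage points lower from compound 1 to compound 3 (beyond the scatter) and a number 18 percentage points lower from compound 1 to compound 2 (beyond the scatter), both showing that placing such a group there lowered the read-out. Going by the values given here, removing tert-butyl alone would thus be expected to move the number back toward compound 1 at 29.8%, while no measured compound carries trifluoromethoxy, so its own contribution is unknown. Compound 4 is therefore expected to give about 20%, within 5% to 40%, an expected change of a number 12.4 percentage points higher from compound 3 to compound 4 (beyond the scatter).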

Compound 4, a percentage reported as activity, at one concentration (the size of the read-out at that concentration, not a potency): 6.45%
Compound 4: middle estimate off by 13.6 percentage points, on the high side; the range from low to high includes it.
By their numbers in this assay, from the lowest: compounds 4, 3 and 2 (each within the scatter of the next); then compound 1.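

In this assay, trifluoromethoxy cannot be told apart from the two alkyl groups at this position (a number 1.2 percentage points lower from compound 3 to compound 4 (within the scatter); a number 5.4 percentage points lower from compound 2 to compound 4 (within the scatter)). Compared with hydrogen, it also goes with a lower read-out (a number 23.4 percentage points lower from compound 1 to compound 4 (beyond the scatter)), so all three groups tested here, including one containing oxygen and fluorine, fall on the same side of compound 1. No measurement shown gives a reason for this.

As far as these compounds go, whether a methyl, a chlorine, an amine or a carboxylic acid on this carbon would stay near compound 1 remains open. A single concentration also leaves the potency of these compounds open.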